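Thiourea-to-thioamide exchange on the phenylpyridazinone chain

This account rests on a few compounds, and the source may have more. Where it says the series, first, only, none or still open, it means among the compounds named here.

Compound 2, `C=CCNC(=S)NCCCCn1nc(-c2ccccc2)ccc1=O`, is the lower of the two measured compounds: in a functional assay on the whole organism with Rattus norvegicus as the target, at a dose of 100 mg/kg (a higher number here means more inhibition at the dose given (going by the name of the read-out), a lower number less inhibition), compound 2 gives 27.1%, whereas compound 1, `CC/N=C(/NC#N)NCCCn1nc(-c2ccccc2)ccc1=O`, gives 62.9%. Going by the values given here, the only measured step, a number 35.8 percentage points lower from compound 1 to compound 2 (beyond the scatter), covers a change of the whole terminal group together with the chain length, so it bears on the present step only in showing that the end group of this chain can move the read-out by a large amount.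

Compound 3, `C/N=C(\S)NCCCCn1nc(-c2ccccc2)ccc1=O`, keeps the chain of compound 2 and differs from it by a group of 4 heavy atoms (2 carbon, 1 nitrogen, 1 sulfur; no ring) in place of a group of 6 heavy atoms (4 carbon, 1 nitrogen, 1 sulfur; no ring), on an amine nitrogen. The entering group carries an imine double bond of the kind also present in compound 1, which stands far higher than compound 2, but nothing measured isolates this part of the change. Because a number 35.8 percentage points lower from compound 1 to compound 2 (beyond the scatter) is large while the present change is smaller, a moderate rise toward the middle of the two values is expected, estimated as a number 10.9 percentage points higher from compound 2 to compound 3 (beyond the scatter). For compound 3 the estimate in this assay is 38%, with a range from 18% to 58%.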

Compound 3, a percentage reported as inhibition, in the whole organism at one dose (the size of the read-out at that dose, not a potency): 87.1%
Compound 3: the middle estimate sits 49.1 percentage points below what was measured; the measured number lies above the stated range.
By their numbers in this assay, from the lowest: compound 2; then compound 1; then compound 3.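

With the chain held fixed, exchange of the group on the amine nitrogen alone gives a number 60 percentage points higher from compound 2 to compound 3 (beyond the scatter) in this assay, so the large effect of the end group no longer rests on a step that also changes chain length. The comparison with the cyano-bearing end group gives a number 24.2 percentage points higher from compound 1 to compound 3 (beyond the scatter), which places compound 3 highest of the three in this assay, although this step changes the chain as well as the end group and cannot assign the gap to either. No measured information on these compounds accounts for the rise.

Going by these compounds alone, the single pair on this amine nitrogen cannot separate the smaller heavy-atom count of the entering group from its other differences, so it remains open how a group such as an ethyl or a cyclopropyl in the same place would read out. Also open is whether the end group of compound 3 holds its number on a longer chain, and the read-out, taken at a single dose, gives no potency for any of these compounds.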